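Little cytotoxicity at the limit of the series

This account rests on a few compounds, and the source may have more. Where it says the series, first, only, none or still open, it means among the compounds named here.

Compound 1 `CC1=CC[C@@H]([C@@](C)(O)CCCC(C)(C)NC=S)CC1` gives 90300 nM
Compound 2 `COc1ccc(/C=N\NC(=S)NC(C)(C)CCC[C@](C)(O)[C@@H]2CC=C(C)CC2)cc1` gives > 100000 nM as a limit
Compound 3 `CC1=CC[C@@H]([C@@](C)(O)CCCC(C)(C)NC(=S)N/N=C\c2ccc(N(C)C)cc2)CC1` gives > 100000 nM as a limit

In a functional assay on HT-29 cells (Homo sapiens) for cytotoxicity, read by sulforhodamine B assay (on this read-out lower numbers stand for higher toxicity in this test and higher numbers for lower toxicity in this test), compound 1 gives 90300 nM and is the only one of the three with a true number. Compound 3 gives > 100000 nM which is a limit of the assay and not a number. Compound 3 therefore stands at the limit of > 100000 nM in this assay, at which 2 of the 3 values shown sit, and has no exact place on the scale.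

Compound 4 `CC1=CC[C@@H]([C@@](C)(O)CCCC(C)(C)NC(=S)N/N=C\c2cccc(Cl)c2)CC1` has not yet been measured. In it, 3-chlorophenyl takes the place of 4-(dimethylamino)phenyl on a carbon with a double bond to nitrogen (3-chlorophenyl in place of 4-(dimethylamino)phenyl on a carbon with a double bond to nitrogen) and this is the whole of the change. Among the measured compounds shown here, the only measured step that bears on it is a step that the two limits leave unreadable from compound 2 to compound 3 and it offers no size to carry over. With no readable step to go on, no change beyond the scatter is expected in this assay and no direction can be favoured. The expected shift is the estimated at least 1.1-fold lower number from compound 3 to compound 4 (0.04 log units; that floor lies within the scatter) and it is small. For the measured compounds named here, this expectation leans on compound 1 at 90300 nM as the sole number available. For compound 4 the estimated value is 90000 nM with an expected range from 35000 nM to 180000 nM and a report as a mere limit would be no surprise.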

Compound 4, concentration lethal to 50% of the cells: 45900 nM
Compound 4: middle estimate off by 2.0-fold (0.29 log units), on the high side; the range from low to high includes it.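

In this assay, among the compounds shown here, the group on a carbon with a double bond to nitrogen proves able to move the read-out: 3-chlorophenyl in place of 4-(dimethylamino)phenyl gives an at least 2.1-fold lower number from compound 3 to compound 4 (0.33 log units; beyond the scatter), the first step at this place whose size can be read at all, since the earlier step between the two limits could not. The change from 4-methoxyphenyl to 3-chlorophenyl gives an at least 2.1-fold lower number from compound 2 to compound 4 (0.33 log units; beyond the scatter), so both substituted phenyl groups that left the read-out at the limit give way to a true number on the same change. The values of compound 2 and compound 3 are limits and not numbers, so each of these steps is only a floor, and its full size stays unknown: the limit of > 100000 nM in this assay, at which 2 of the 4 values shown sit.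

The compounds shown leave open whether the chlorine itself or merely the loss of the dimethylamino or methoxy group accounts for the step, a question that a plain phenyl group at this place would address. They also leave open whether a bromine or a trifluoromethyl group in place of the chlorine would carry the number further in the same direction.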